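The source may report more compounds than this note shows. Statements on the series, on what has been measured and on what is new or still open speak of the compounds shown alone.

In a functional assay on WM 266-4 cells (Homo sapiens) for antiproliferative activity, read by MTT assay, with a stated time of 24 h (a lower number here means a stronger inhibitor of growth, a higher number a weaker inhibitor of growth), three compounds with a shared core have been measured: compound 1 (`c1ccc(COc2ccc(C3CC(c4ccc5c(c4)OCCO5)=NN3c3ccccc3)cc2)cc1`) stands at 1130 nM while compound 3 (`c1ccc(COc2cccc(C3CC(c4ccc5c(c4)OCCO5)=NN3c3ccccc3)c2)cc1`) stands at 870 nM and compound 2 (`COc1ccc(C2CC(c3ccc4c(c3)OCCO4)=NN2c2ccccc2)cc1OC`) at 2160 nM on the same scale. Compound 2 lies within the scatter of compound 1, while its number lies beyond the scatter above that of compound 3. Compound 4 (`Brc1ccc(C2CC(c3ccc4c(c3)OCCO4)=NN2c2ccccc2)cc1`) has not yet been measured. Compared with compound 2, it has 4-bromophenyl in place of 3,4-dimethoxyphenyl on a saturated ring carbon. Within the data shown here, no measured pair shows this change alone, so the only guide is the values of compound 1 (1130 nM) and compound 3 (870 nM), which also lack 3,4-dimethoxyphenyl. A small move toward a lower number in this assay, possibly not clearing the scatter, is expected, and the estimated step is (a 1.8-fold lower number from compound 2 to compound 4 (0.26 log units; within the scatter)). For compound 4 the expected value is 1200 nM with an estimated range from 500 nM to 2800 nM in this assay.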

Compound 4, concentration for 50% growth inhibition: 3010 nM
Estimate against measurement, compound 4: 2.5-fold (0.40 log units) below, outside the stated range (above it).
By their numbers in this assay, from the lowest: compounds 3, 1, 2 and 4 (each within the scatter of the next, the first and the last beyond it).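

In this assay, 4-bromophenyl in place of 3,4-dimethoxyphenyl on a saturated ring carbon gives a 1.4-fold higher number from compound 2 to compound 4 (0.14 log units; within the scatter), so this position accepts the exchange of a group with two hydrogen-bond acceptors for one with none without a change that can be told from the scatter. Among these compounds, the second comparison is the first step at this position to clear the scatter: bromo in place of benzyloxy on an aromatic carbon gives a 2.7-fold higher number from compound 1 to compound 4 (0.43 log units; beyond the scatter), so at this position the benzyloxy group of compound 1 separates from the bromo group of compound 4. Nothing available explains either step.

Going by these compounds, it remains open how an amine or a carboxylic acid on this aromatic ring would compare with bromo or benzyloxy. On these data alone, it is also open whether a longer chain, such as a phenethyloxy group, would move the number further than benzyloxy does.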